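Adding a Methoxy Group to a Weak Growth Inhibitor

A few compounds are considered here, and "the series" means these few. Any claim that something is new, unique, unknown or untested is made for them only; others in the source may bear on it.

Of the compounds shown here, two have been tested in a functional assay on cells (CNS carcinoma cell, Homo sapiens) for cytotoxicity, read by sulforhodamine B assay, with a stated time of 48 h; on this read-out higher numbers stand for weaker inhibition of growth and lower numbers for stronger inhibition of growth. Compound 1 `COc1ccc2c(c1)/C(=C/c1c(-c3ccncc3)nc3sccn13)C(=O)N2C` gives 63100 nM in this assay, and compound 2 `COc1nc2sc(C)cn2c1/C=C1/C(=O)Nc2ccccc21` gives 40100 nM. Both numbers are high, so neither compound inhibits growth strongly, and the gap between them lies within the usual scatter, so compound 2 cannot be placed above or below compound 1 with any confidence.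

Compound 3 `COc1ccc2c(c1)/C(=C\c1c(OC)nc3sc(C)cn13)C(=O)N2` has not yet been measured. It differs from compound 2 in one counted place: methoxy in place of hydrogen on an aromatic carbon. For the measured compounds named here, the change is small, and the only other compound here that carries a methoxy group on a ring of this kind, compound 1, gives 63100 nM, a weak result as well.

Going by the values given here, with no measured step showing what this change does, compound 3 is expected to stay close to compound 2, with a step of a 1.0-fold lower number from compound 2 to compound 3 (0.00 log units; within the scatter) that is not beyond the scatter. The estimate for compound 3 is therefore 40000 nM, within a range of 15000 nM to 110000 nM.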

Compound 3, concentration for total growth inhibition: 33600 nM
Estimate against measurement, compound 3: 1.2-fold (0.08 log units) above, within the range that was stated.
By their numbers in this assay, from the lowest: compounds 3, 2 and 1 (each within the scatter of the next).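

In this assay, for the compounds shown here, methoxy in place of hydrogen on an aromatic carbon of the six-membered aromatic ring of carbon only gives a 1.2-fold lower number from compound 2 to compound 3 (0.08 log units; within the scatter) and so provides the one measured step at this position. It shows that this position can carry methoxy with no change in growth inhibition that can be told apart from the scatter, something compounds 1 and 2 alone could not show. Nothing measured here accounts for the size of this step.

Going by these compounds, whether a different group at this position, such as an amine, a carboxylic acid or a longer chain like ethoxy, would shift the number beyond the scatter remains open. Also open, on these data alone, is whether any change to this position could turn these weak growth inhibitors into strong ones.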